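The compounds below may be only part of what the source reports. "The series", "measured", "known", "first", "only" and "open" are said of these compounds alone.

In an in vitro ADME assay on microsomes from liver (Homo sapiens) for pharmacokinetics, read by LC-MS, with a stated time of 10 min, tested at 1 uM (a higher number here means faster removal of the compound, a lower number slower removal), three compounds built on a shared core have been measured. Compound 1 `CN1C[C@H](C(=O)Nc2ccc(F)cc2)[C@@H](c2ccc(/C=C/C(=O)Nc3ccccc3N)cc2)C1` gives 5 mL/min/kg, compound 2 `CN1C[C@H](C(=O)Nc2ccc(F)c(Cl)c2)[C@@H](c2ccc(/C=C/C(=O)Nc3ccccc3N)cc2)C1` gives 15 mL/min/kg, and compound 3 `Nc1ccccc1NC(=O)/C=C/c1ccc([C@H]2CN(C3COC3)C[C@@H]2C(=O)Nc2ccc(Cl)cc2)cc1` gives 13 mL/min/kg. Compound 3 therefore lies within the scatter of compound 2 and beyond the scatter above compound 1.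

Compound 4 `Nc1ccccc1NC(=O)/C=C/c1ccc([C@H]2CN(C3CCOCC3)C[C@@H]2C(=O)Nc2ccc(Cl)cc2)cc1` differs from compound 3 in one place: oxan-4-yl in place of oxetan-3-yl on an amine nitrogen in a ring, with oxan-4-yl in place of oxetan-3-yl on an amine nitrogen in a ring. Among the compounds with values here, the only measured step, a 3.0-fold higher number from compound 1 to compound 2 (0.48 log units; beyond the scatter), is modest and beyond the scatter, but it is a chloro in place of hydrogen on an aromatic carbon, a different change at a different place. It offers no direct guide to the size of this one. The expectation therefore rests on compound 3 at 13 mL/min/kg, and no step beyond the scatter is expected in this assay. The expected change is a 1.2-fold higher number from compound 3 to compound 4 (0.09 log units; within the scatter). The clearance of compound 4 is estimated at 16 mL/min/kg, with an expected range of 8 mL/min/kg to 32 mL/min/kg.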

Compound 4, clearance: 12 mL/min/kg
Compound 4: the middle estimate sits 1.3-fold (0.12 log units) above what was measured; low and high end bracket the measured number.
By their numbers in this assay, from the lowest: compound 1; then compounds 4, 3 and 2 (each within the scatter of the next).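

In this assay, oxan-4-yl in place of oxetan-3-yl on the amine nitrogen in a ring gives a 1.1-fold lower number from compound 3 to compound 4 (0.03 log units; within the scatter) and so no step beyond the scatter. Within the data shown here, the only earlier step was a chloro change on an aromatic carbon, whereas this pair gives a first reading at the nitrogen: here, going from a four-membered ring with 4 heavy atoms to a six-membered ring with 6 heavy atoms leaves the clearance within the scatter. Nothing available bears on why this swap leaves the number within the scatter.

Both groups carry a ring oxygen, so the compounds shown leave open whether a cyclohexyl or a piperidin-4-yl group at this nitrogen would read the same. They also leave open whether this result holds with an aryl group other than the 4-chlorophenyl of this pair.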